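The source may hold more compounds than are shown below. What is called first, only, known or untested is meant among the compounds shown, and "the series" means these compounds.

Compound 1 `COc1ncc(-c2ccc3c(c2)N(c2ccc(C)cc2)C(=O)CO3)cc1NS(=O)(=O)c1ccc(F)cc1` gives the lowest number of the three compounds measured in a functional assay on HeLa cells (Homo sapiens) for antiproliferative activity, read by MTT assay, with a stated time of 72 h (on this read-out lower numbers stand for stronger inhibition and higher numbers for weaker inhibition), at 4650 nM. Compound 2 `Cc1ccc(N2C(=O)COc3ccc(-c4cnc(Cl)c(NS(=O)(=O)c5ccc(F)cc5)c4)cc32)cc1` gives 32300 nM in this assay, and compound 3 `O=C1COc2ccc(-c3cccc(NS(=O)(=O)c4ccc(F)cc4)c3)cc2N1C1CCCCC1` gives 10800 nM.

Compound 4 `COc1ncc(-c2ccc3c(c2)N(C(C)C)C(=O)CO3)cc1NS(=O)(=O)c1ccc(F)cc1` differs from compound 1 in one place: isopropyl in place of 4-methylphenyl on an amide-type nitrogen in a ring. Among the compounds with values here, the one measured step, a 6.9-fold higher number from compound 1 to compound 2 (0.84 log units; beyond the scatter), concerns a different position of the shared core and so says nothing direct about a change on the amide-type nitrogen. Compound 3 carries a non-aromatic group on that nitrogen, but it also lacks the substituted pyridine of compound 1, so its value cannot be read as a step for this change; what the two values show is that compound 3 sits higher than compound 1 in this assay.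

Within the data shown here, with no matching step, the expectation rests on a modest weakening, and compound 4 is estimated at 8000 nM, within a range from 3000 nM to 25000 nM, a step of a 1.7-fold higher number from compound 1 to compound 4 (0.24 log units; within the scatter) that is expected rather than established.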

Compound 4, half-maximal inhibitory concentration: 2790 nM
Compound 4: the middle estimate sits 2.9-fold (0.46 log units) above what was measured; measured number below the stated range.
By their numbers in this assay, from the lowest: compounds 4 and 1 (each within the scatter of the next); then compound 3; then compound 2.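

On the amide-type nitrogen, isopropyl in place of 4-methylphenyl gives a 1.7-fold lower number from compound 1 to compound 4 (0.22 log units; within the scatter) in this assay and stays within the scatter, so the two values cannot be told apart on this read-out. Within the data shown here, this is the first direct step at this position: with the rest of the molecule unchanged, a six-membered aromatic ring of carbon leaves, a smaller group with no ring enters, and the number does not move beyond the scatter. No evidence is available that accounts for this result.

The compounds shown leave open whether a longer chain, or a chain carrying an amine or a carboxylic acid, would be tolerated on this nitrogen. They also leave open whether isopropyl would give a similar result with chloro in place of methoxy, as in compound 2.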